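The source may hold more compounds than are shown below. What is called first, only, known or untested is meant among the compounds shown, and "the series" means these compounds.

Of the compounds shown here, three built on one shared core have been measured in a functional assay on HT-29 cells (Homo sapiens) for cytotoxicity, read by sulforhodamine B assay; a higher number here means a weaker inhibitor, a lower number a stronger inhibitor. Compound 1 `C=C1[C@@H](C/C=C2/C(=O)OC[C@H]2OC(C)=O)[C@]2(C)CC[C@@H](OC(C)=O)[C@@](C)(CO[Si](C)(C)C(C)(C)C)[C@H]2C[C@@H]1O` gives 9310 nM. Compound 2 `C=C1[C@@H](OC(C)=O)C[C@@H]2[C@](C)(COC=O)[C@H](OC(C)=O)CC[C@@]2(C)[C@@H]1C[C@@H](Nc1ccc(Br)cc1)C1=CCOC1=O` gives 13200 nM. Compound 3 `C=C1[C@@H](OC(C)=O)C[C@@H]2[C@](C)(CO[Si](C)(C)C(C)(C)C)[C@H](OC(C)=O)CC[C@@]2(C)[C@@H]1C[C@@H](Nc1ccc(F)cc1)C1=CCOC1=O` gives 4940 nM. Compound 2 carries the highest of the three numbers; the number of compound 1 lies within the scatter of it, while the number of compound 3 lies beyond the scatter, below it. Compound 4 `C=C1[C@@H](OC(C)=O)C[C@@H]2[C@](C)(COC=O)[C@H](OC(C)=O)CC[C@@]2(C)[C@@H]1C[C@@H](Nc1ccccc1F)C1=CCOC1=O` has not yet been measured. It differs from compound 2 in one place: 2-fluorophenyl in place of 4-bromophenyl on an amine nitrogen. Among the compounds with values here, no measured pair shows this change by itself, so nothing here sets its size. The expected step from compound 2 to compound 4 is small, within the scatter, in no settled direction, and the estimated step is a 1.2-fold lower number from compound 2 to compound 4 (0.08 log units; within the scatter). For compound 4 the estimate is 11000 nM, with a range from 4000 nM to 30000 nM.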

Compound 4, half-maximal inhibitory concentration: 9760 nM
Estimate against measurement, compound 4: 1.1-fold (0.05 log units) above; low and high end bracket the measured number.
By their numbers in this assay, from the lowest: compounds 3, 1, 4 and 2 (each within the scatter of the next, the first and the last beyond it).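

In this assay, 2-fluorophenyl in place of 4-bromophenyl on the amine nitrogen gives a 1.4-fold lower number from compound 2 to compound 4 (0.13 log units; within the scatter), so this exchange of aryl groups on the shared core leaves the number within the scatter. Because the halogen and its numbered position change together, this single step cannot separate the two. Nothing given here accounts for the step. Still open, going by these compounds, is how an unsubstituted phenyl, a pyridine ring or a benzyl group on this nitrogen would compare with compound 2.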